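The compounds below may be only part of what the source reports. "The series", "measured", "known", "first", "only" and "open" are said of these compounds alone.

Compound 1, with the structure `CC(=O)N1CCC(c2ccc(-c3cc(C(=O)O)cc4cc(-c5ccc(C(F)(F)F)cc5)ccc34)cc2)CC1`, was tested in a functional assay on the whole organism (strain ICR) for inhibition, with Mus musculus as the target, with stated times of 7 days and 1 h, at a dose of 10 umol/kg by the intraperitoneal route; on this read-out higher numbers stand for more inhibition at the one dose given (going by the name of the read-out) and lower numbers for less inhibition. In that assay compound 1 gives 100%, the highest of the two numbers recorded so far. The nearest value belongs to compound 2, `O=C(O)c1cc(-c2ccc(C3CCNCC3)cc2)cc(-c2cn(-c3ccc(C(F)(F)F)cc3)nn2)c1`, which differs from compound 1 in more than one place; in this assay compound 2 gives 86.8%, and the gap between compound 1 and compound 2 lies beyond the usual scatter of repeated measurements. Going by the values given here, since the two differ at several points, no single step between them can be drawn.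

Compound 3, `C#CCCCCN1CCC(c2ccc(-c3cc(C(=O)O)cc4cc(-c5ccc(C(F)(F)F)cc5)ccc34)cc2)CC1`, has not yet been measured. It differs from compound 1 in one place: hex-5-yn-1-yl in place of acetyl on an amine nitrogen in a ring. The entering chain carries a triple bond where the acetyl carried a double bond, and it brings no oxygen.

Because compound 1 gives 100%, a value at the top of this read-out, the change is expected to be at most a modest loss, a number 8 percentage points lower from compound 1 to compound 3 (within the scatter). Compound 3 is therefore expected to give about 92% in this assay, with a likely range from 70% to 100%.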

Compound 3, a percentage reported as inhibition, in the whole organism at one dose (the size of the read-out at that dose, not a potency): 75.9%
Compound 3: the middle estimate sits 16.1 percentage points above what was measured; measured number inside the range.
By their numbers in this assay, from the lowest: compound 3; then compound 2; then compound 1.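

Going by these compounds alone, on the amine nitrogen in the ring, putting hex-5-yn-1-yl in place of acetyl on the core of compound 1 comes with a number 24.1 percentage points lower from compound 1 to compound 3 (beyond the scatter) in this assay and gives the first reading of a change at a single place, which shows that the group at this position matters to the result at this dose. The change does not remove the effect, however: compound 3 still gives 75.9% at the one dose tested, so inhibition survives a six-carbon chain that has no oxygen and no hydrogen-bond acceptor. Nothing measured here tells why the number falls with this change.

On these data alone, this one step removes the carbonyl, lengthens the chain and brings in a triple bond all at once, so it remains open which of these goes with the lower number. A hexanoyl group, which would keep the carbonyl on a longer chain, or a plain hexyl chain, which would have no triple bond, would separate these changes if placed on the same nitrogen.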